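Removing the Pentyl From a Selenium: a Second Instance

The compounds below may be only part of what the source reports. "The series", "measured", "known", "first", "only" and "open" are said of these compounds alone.

Compound 1 `CCCCC[Se]c1nc(NCc2ccc(SC)cc2)c2ccccc2n1` carries a pentyl on a selenium and a methylsulfanyl on a six-membered aromatic ring of carbon only. In a functional assay on HTB-54 cells (Homo sapiens) for cytotoxicity, read by MTT assay, with a stated time of 72 h (a lower number here means a stronger inhibitor of growth, a higher number a weaker inhibitor of growth), compound 1 gives 81300 nM. Compound 2 `CSc1ccc(CNc2nc([SeH])nc3ccccc23)cc1` differs from compound 1 in one place: hydrogen in place of pentyl on a selenium. In this assay compound 2 gives only a limit of the assay, > 100000 nM. The step is an at least 1.2-fold higher number from compound 1 to compound 2 (0.08 log units; that floor lies within the scatter); its floor rests on (the limit of > 100000 nM in this assay, at which 1 of the 3 values shown sits). Compound 3 `CCCCC[Se]c1nc(NCc2ccccc2)c2ccccc2n1` differs from compound 1 in another place: hydrogen in place of methylsulfanyl on an aromatic carbon. In this assay compound 3 gives 81100 nM, which is a 1.0-fold lower number from compound 1 to compound 3 (0.00 log units; within the scatter), so the two values show no real difference.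

Compound 4 `[SeH]c1nc(NCc2ccccc2)c2ccccc2n1` has not yet been measured in this assay. Its difference from compound 3 is hydrogen in place of pentyl on a selenium, the same change as that from compound 1 to compound 2, at the same kind of place, a selenium whose other neighbour is an aromatic carbon. The step from compound 3 to compound 4 is expected to be a 1.8-fold higher number from compound 3 to compound 4 (0.27 log units; within the scatter), resting on the earlier step of an at least 1.2-fold higher number from compound 1 to compound 2 (0.08 log units; that floor lies within the scatter) and on compound 3 sitting at 81100 nM. Compound 4 is therefore estimated at 150000 nM, with a likely range from 70000 nM to 400000 nM, and it is expected that this assay may again report only a limit for compound 4 rather than a number.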

Compound 4, concentration for total growth inhibition: > 100000 nM
Compound 4: only a limit was reported; the forecaster's own chance of this, stated with the estimate: 70%; the middle value does not contradict the limit.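

In this assay, replacing the pentyl on the selenium with a hydrogen on the simpler core gives an at least 1.2-fold higher number from compound 3 to compound 4 (0.09 log units; that floor lies within the scatter), a step that rests on a limit of the assay for compound 4 and not on a true number. Set beside the same change on the core of compound 1, this result is compatible with the earlier one but cannot establish that the two steps match: the same change on two cores in this assay, an at least 1.2-fold higher number (0.08 log units; that floor lies within the scatter) from compound 1 to compound 2 and an at least 1.2-fold higher number (0.09 log units; that floor lies within the scatter) from compound 3 to compound 4; the limit leaves it open whether they differ. What carries over is modest, since on both cores the compound with hydrogen on the selenium ends at the assay's limit, and the data show neither a real loss of growth inhibition nor the true size of either step: the limit of > 100000 nM in this assay, at which 2 of the 4 values shown sit.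

As far as these compounds go, both compounds with hydrogen on the selenium are reported only as limits, so the step between them, hydrogen in place of methylsulfanyl, cannot be read, and it remains open whether methylsulfanyl matters once the pentyl is gone. Also open, from the compounds shown here alone, is whether a shorter chain such as ethyl, a longer chain such as octyl, or a chain ending in a carboxylic acid on the selenium would give a value clearly apart from those of compound 1 and compound 3.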